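The source may report more compounds than this note shows. Statements on the series, on what has been measured and on what is new or still open speak of the compounds shown alone.

Compound 1 `N=C(NCCCc1c[nH]cn1)NCCCC(c1ccc(F)cc1)c1ccccn1`: in a functional assay on cardiac atrium for agonist activity at histamine H2 receptor (Cavia porcellus) (on this read-out higher numbers stand for larger maximal responses and lower numbers for smaller maximal responses), compound 1 gives 0.9.
Compound 2 `N=C(NCCCc1c[nH]cn1)NCCC(c1ccc(Cl)cc1)c1ccccn1`: in this assay compound 2 gives 1.
Compound 3 `N=C(NCCCc1c[nH]cn1)NCCC(c1ccc(Br)cc1)c1ccccn1`: in this assay compound 3 gives 1.

Compound 3 stands level with compound 2 at the digits shown, and together they hold the highest of the three numbers; compound 1 sits a little lower, but that gap lies within the scatter, so no order among the three can be claimed. Among the measured compounds shown here, the only single-place step among the measured compounds is no change at the digits printed from compound 2 to compound 3 (within the scatter), a swap of one halogen for another on the aromatic ring, which moved nothing beyond the scatter.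

Compound 4 `N=C(NCCCc1c[nH]cn1)NCCC(c1cccc(F)c1)c1ccccn1` differs from compound 3 in this way: 3-fluorophenyl in place of 4-bromophenyl on a saturated chain carbon bound to an aromatic carbon and a saturated chain carbon. This step bears on the measured one only in part, since both the halogen and its place on the ring change. The fluorine-bearing ring of compound 1 is some guide: compound 1 gives 0.9 while compound 3 gives 1, two values within the scatter of each other. With every halogen variant so far reaching the reference agonist's response or close to it, the expected step a number 0.050 lower from compound 3 to compound 4 (within the scatter) is none beyond the scatter. For compound 4 the estimate in this assay is 0.95, with a range from 0.8 to 1.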

Compound 4, intrinsic activity: the largest response reached, as a fraction of the reference agonist's: 1
Compound 4: middle estimate off by 0.050, on the low side; measured number inside the range.
By their numbers in this assay, from the lowest: compounds 1, 2, 3 and 4 (each within the scatter of the next).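

In this assay, moving to 3-fluorophenyl on a saturated chain carbon bound to an aromatic carbon and a saturated chain carbon gives no change at the digits printed from compound 3 to compound 4 (within the scatter), and the same change starting from 4-chlorophenyl gives no change at the digits printed from compound 2 to compound 4 (within the scatter). The earlier single-place step only exchanged one halogen for another within the 4-substituted phenyl group, whereas these steps change both the halogen and its place on the ring, and the maximal response still stays within the scatter. The two changes arrive together in each step, so their separate contributions cannot be read, and nothing shown here offers a reason for the outcome.

Going by these compounds, what a phenyl group carrying no halogen, or one carrying an amine or a carboxylic acid in place of the halogen, would do at this position remains open, as does the outcome for 3-fluorophenyl on a longer chain. On these data alone, the read-out speaks only of the largest response reached, so how much of each compound is needed to reach it also remains open.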